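The compounds below may be only part of what the source reports. "The series", "measured", "known", "first", "only" and "open" are said of these compounds alone.

The series rests on a shared core, seen in compound 1 `O=C1c2c(O)cccc2O[C@H](c2cccc(O)c2O)[C@H]1O` and compound 2 `O=C1c2ccccc2O[C@@H](c2cccc(O)c2O)[C@@H]1O`. In a functional assay on RAW264.7 cells (Rattus norvegicus) for inhibition, with RAW264.7 (Mus musculus) as the target, read by Griess assay, with stated times of 2 h and 16 h (on this read-out higher numbers stand for weaker inhibition and lower numbers for stronger inhibition), compound 1 gives 77700 nM. For compound 2 the result in this assay is only a limit, > 100000 nM, so no number stands for it. That reading sits at the limit of > 100000 nM in this assay, at which 1 of the 2 values shown sits, and compound 2 therefore stands at the weak end of the values shown, with nothing more precise known about it. Within the data shown here, no step between two measured compounds is available, so the effect of any single change has not been measured here. Compound 3 `O=C1c2c(O)cccc2O[C@@H](c2cccc(O)c2O)[C@@H]1O` is the next compound; it differs from compound 2 by hydroxy in place of hydrogen on an aromatic carbon. Among the measured compounds shown here, compound 1 carries the same hydroxy group and gives 77700 nM in this assay, the only number in the set. On that basis the step from compound 2 to compound 3 is expected to move toward stronger inhibition, though the amount is uncertain, compound 2 being known only as a limit. Compound 3 is accordingly estimated at 80000 nM in this assay, with a range from 30000 nM to 200000 nM, and an expected step of an at least 1.2-fold lower number from compound 2 to compound 3 (0.09 log units; that floor lies within the scatter).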

Compound 3, half-maximal inhibitory concentration: > 100000 nM
Compound 3: a limit, no number; the forecaster's own chance of this, stated with the estimate: 40%; at least 1.2-fold (0.09 log units) between middle value and limit.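

Compound 3 gives > 100000 nM in this assay, which is a limit and not a number, so hydroxy in place of hydrogen on this aromatic carbon, ortho to a fused ring and meta to a fused ring, leaves the compound at the limit where compound 2 already stands: the limit of > 100000 nM in this assay, at which 2 of the 3 values shown sit.

With compound 2 and compound 3 both known only as limits, the step between them cannot be read. The one readable step is an at least 1.2-fold higher number from compound 1 to compound 3 (0.10 log units; that floor lies within the scatter), a floor that does not establish any difference between the two drawn configurations, and this pair isolates that single kind of change: the fact that compounds 1 and 3 differ only in the configuration as drawn

The compounds shown leave open whether hydroxy in place of hydrogen at this position has any readable effect in this assay, in either configuration as drawn. They also leave open how a methoxy group or an amine on the same aromatic carbon would read there, and whether either would give a number rather than a limit.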